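The compounds below may be only part of what the source reports. "The series", "measured", "known", "first", "only" and "open" are said of these compounds alone.

Compound 3 `O=C(N/N=C/c1ccccc1O)c1cccc(S(=O)(=O)N2CCOCC2)c1` belongs to a small set of compounds built on one shared core and tested in a functional assay on PC-3 cells (Homo sapiens) for antiproliferative activity, read by MTT assay, with a stated time of 72 h; a higher number here means a weaker inhibitor, a lower number a stronger inhibitor. In this assay compound 3 gives 13800 nM, the higher of the two numbers obtained; the nearest is compound 2 `C/C(=N\NC(=O)c1cccc(S(=O)(=O)N2CCOCC2)c1)c1cc(Br)ccc1O`, which in this assay gives 6890 nM, and the gap between the two lies within the scatter of such measurements. Compound 1 `C/C(=N\NC(=O)c1cccc(S(=O)(=O)N2CCOCC2)c1)c1cc(O)ccc1O` stands apart: in this assay compound 1 gives > 100000 nM, which is a limit of the assay and not a number (the limit of > 100000 nM in this assay, at which 1 of the 3 values shown sits).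

Compound 4 `O=C(N/N=C/c1cc(Br)ccc1O)c1cccc(S(=O)(=O)N2CCOCC2)c1` has not yet been measured in this assay. It differs from compound 3 in one place: bromo in place of hydrogen on an aromatic carbon. Within the data shown here, the only measured step that bears on this change is the one from compound 1 to compound 2, an at least 14-fold lower number from compound 1 to compound 2 (1.16 log units; beyond the scatter), where a bromo also entered; there, however, it replaced a hydroxy and not a hydrogen, so it points only loosely to the change in compound 4. On that basis a move to a lower number is expected for compound 4 in this assay, modest in size and close to the edge of the scatter, a 2.5-fold lower number from compound 3 to compound 4 (0.40 log units; beyond the scatter). The estimate for compound 4 in this assay is 5500 nM, within a range from 1500 nM to 16000 nM.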

Compound 4, half-maximal inhibitory concentration: 7230 nM
The estimate for compound 4 lay 1.3-fold (0.12 log units) below the measured number; the measured number falls inside the stated range.
By their numbers in this assay, from the lowest: compounds 2, 4 and 3 (each within the scatter of the next). At a limit, above all of these: compound 1.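

Among these compounds, compound 4 gives the first direct reading of bromo replacing hydrogen at this position, para to the hydroxy group, and in this assay the change amounts to a 1.9-fold lower number from compound 3 to compound 4 (0.28 log units; within the scatter). Among the compounds shown here, on the 2-hydroxyphenyl group, then, the entry of a bromo in place of hydrogen does not move the number beyond the scatter, which the earlier compounds could not show. The large step seen before, an at least 14-fold lower number from compound 1 to compound 2 (1.16 log units; beyond the scatter), therefore cannot be read as a general effect of bromo at this position, since there a hydroxy left as the bromo entered and compound 1 stands at a limit of the assay, while none of the data shown gives a measured reason for either step.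

From the compounds shown here alone, it remains open whether other groups at this position, such as a chlorine, a methoxy group or an amine, would also stay within the scatter of hydrogen and bromo. For the compounds shown here, whether the hydroxy group alone sets a compound apart also stays unsettled, as the only compound carrying it at this position is compound 1.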